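The source may hold more compounds than are shown below. What is called first, only, known or untested is meant among the compounds shown, and "the series" means these compounds.

In a functional assay on HeLa cells (Homo sapiens) for inhibition (a lower number here means a stronger inhibitor, a higher number a weaker inhibitor), compound 3 `Oc1ccccc1-c1cc(-c2cccc(C(F)(F)F)c2)cc(-c2ccccc2O)n1` is known only through a limit, giving > 50000 nM. Compound 1 `Oc1ccccc1-c1cc(-c2cccc(F)c2)cc(-c2ccccc2O)n1` in this assay also stops at a limit, giving > 50000 nM. Compound 2 `Oc1ccccc1-c1cc(-c2ccccc2C(F)(F)F)cc(-c2ccccc2O)n1` in this assay gives 5800 nM. Moving the trifluoromethyl from one position to another brings an at least 8.6-fold higher number from compound 2 to compound 3 (0.93 log units; beyond the scatter), and the step of an at least 8.6-fold lower number from compound 1 to compound 2 (0.93 log units; beyond the scatter) points the same way, while a step that the two limits leave unreadable from compound 1 to compound 3 is hidden by the limit of > 50000 nM in this assay, at which 2 of the 3 values shown sit. Compound 4 `Oc1ccccc1-c1cc(-c2cccc(OC(F)(F)F)c2)cc(-c2ccccc2O)n1` keeps the shared core of compound 3 and differs only in that (trifluoromethoxy in place of trifluoromethyl on an aromatic carbon). Both measured compounds carrying a group at that position sit at the limit, so the step is expected to be a number no higher from compound 3 to compound 4 (the limit leaves the size open). Compound 4 is therefore estimated at 50000 nM, with a range from 15000 nM to 200000 nM.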

Compound 4, half-maximal inhibitory concentration: > 50000 nM
Compound 4 gave a limit, no number; the forecaster's own chance of this, stated with the estimate: 75%; the middle value lies on the limit itself.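

Within the data shown here, compound 4 ends at a limit in this assay, so no step from compound 1 or compound 3 to compound 4 can be read: the limit of > 50000 nM in this assay, at which 3 of the 4 values shown sit. The compounds shown leave open how compound 1, compound 3 and compound 4 rank against one another.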